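The source may report more compounds than this note shows. Statements on the series, on what has been measured and on what is new or still open speak of the compounds shown alone.

Measured so far:
compound 1 `CSc1nnc(-c2ccc(Cl)cc2)n1C` — > 200 mg/kg
compound 2 `CCn1c(SC)nnc1-c1ccc(Cl)cc1` — > 50 mg/kg
compound 3 `Cn1c(-c2ccccc2F)nnc1S(C)(=O)=O` — > 100 mg/kg

In a functional assay on the whole organism for antagonist activity, with Mus musculus as the target, in the maximal electroshock model (on this read-out lower numbers stand for an effect already at smaller amounts and higher numbers for an effect only at larger amounts of compound), compound 1 reaches only a limit, > 200 mg/kg. Compound 2 likewise gives only a limit in this assay, namely > 50 mg/kg. Compound 3 also stops at a limit, > 100 mg/kg. The change methyl in place of hydrogen on a saturated chain carbon bound to an aromatic nitrogen gives the step that the two limits leave unreadable from compound 1 to compound 2; it stays unreadable (the limit of > 200 mg/kg in this assay, at which 1 of the 3 values shown sits, (the limit of > 50 mg/kg in this assay, at which 1 of the 3 values shown sits)). The difference between the core of compound 1 and the core of compound 3 is not broken down here.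

Compound 4 `CCS(=O)(=O)c1nnc(-c2ccccc2F)n1C` differs from compound 3 by methyl in place of hydrogen on a saturated chain carbon bound to a sulfonyl sulfur. This is the same kind of change as that from compound 1 to compound 2, not the same one: here the place is on a saturated chain carbon bound to a sulfonyl sulfur, there on a saturated chain carbon bound to an aromatic nitrogen.

Compound 3 sits at a limit (the limit of > 100 mg/kg in this assay, at which 1 of the 3 values shown sits), and the earlier step of the same kind, a step that the two limits leave unreadable from compound 1 to compound 2, cannot be sized. Compound 4 is therefore expected to remain weak, with the step that the limit leaves unreadable from compound 3 to compound 4 estimated as small. For compound 4 the estimate in this assay is 150 mg/kg, expected between 50 mg/kg and 400 mg/kg.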

Compound 4, dose for half-maximal effect: > 200 mg/kg
Compound 4 was reported as a limit; the forecaster's own chance of this, stated with the estimate: 80%; middle value at least 1.3-fold (0.12 log units) from the limit.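

The step between compound 3 and compound 4 cannot be read, as both results in this assay are limits. The compounds shown leave open what dose for half-maximal effect any of them has, and what size either methyl change has.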